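A few compounds are considered here, and "the series" means these few. Any claim that something is new, unique, unknown or untested is made for them only; others in the source may bear on it.

Of the compounds shown here, three built on a shared fused core have been tested in a functional assay on M14 cells (Homo sapiens) for cytotoxicity, read by sulforhodamine B assay, with a stated time of 48 h; a lower number here means a stronger inhibitor of growth, a higher number a weaker inhibitor of growth. Compound 1 `ClCc1ccc(Cn2cnc3c(Cl)ncnc32)cc1` gives 1280 nM, compound 2 `ClCc1ccccc1Cn1cnc2c(Cl)nc(Cl)nc21` gives 1380 nM, and compound 3 `ClCc1ccccc1Cn1cnc2ncnc(Cl)c21` gives 1900 nM. Compound 2 shows the second highest of the three numbers, yet its gap to each of the others lies within the usual scatter, so none of the three can be set apart. Compound 4 `Nc1nc(Cl)c2ncn(Cc3ccccc3CCl)c2n1` has not yet been measured; it differs from compound 2 in one place: amino in place of chloro on an aromatic carbon, an amino in place of chloro on an aromatic carbon. Among the measured compounds shown here, no measured pair shows this change, so nothing fixes its size or direction, and the expectation is a step that stays within the scatter. Compound 4 is therefore expected to give 1800 nM, within a range from 700 nM to 4500 nM, an expected step of a 1.3-fold higher number from compound 2 to compound 4 (0.12 log units; within the scatter).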

Compound 4, concentration for 50% growth inhibition: 5750 nM
For compound 4 the middle estimate is 3.2-fold (0.50 log units) below the measured one, and the stated range ends below it.
By their numbers in this assay, from the lowest: compounds 1, 2 and 3 (each within the scatter of the next); then compound 4.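

In this assay, the aromatic carbon between two ring nitrogen atoms is shown to matter: amino in place of chloro there gives a 4.2-fold higher number from compound 2 to compound 4 (0.62 log units; beyond the scatter). Among the compounds shown here, this is the only step in the set that can be read, and it points to weaker growth inhibition with the amino group on this carbon. No measurement shown accounts for this step.

From the compounds shown here alone, whether this shift is specific to the amino group remains open. A methoxy or methylamino group on the same carbon could show whether other replacements for chloro move the number as far.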